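Ring size at the amino nitrogen of compound 3

The source may hold more compounds than are shown below. What is called first, only, known or untested is meant among the compounds shown, and "the series" means these compounds.

In an assay on CHO cells for displacement of a labelled ligand from adenosine receptor A1 (Homo sapiens), read by scintillation counting, with a stated time of 3 h (on this read-out higher numbers stand for weaker inhibition and lower numbers for stronger inhibition), compound 3 `Cn1c(-c2ccccc2)nc2c(NC3CCCCC3)ncnc21` gives 5.7 nM, the lowest of the three numbers in hand, although none of its neighbours stands apart from it beyond the scatter: compound 2 `Cn1c(-c2cccc(Cl)c2)nc2c(NC3CCCC3)ncnc21` gives 6.5 nM, and compound 1 `CCn1c(-c2ccccc2)nc2c(NC3CCCCC3)ncnc21` gives 10 nM. Among the compounds with values here, the only step measured in one place, a 1.8-fold lower number from compound 1 to compound 3 (0.24 log units; within the scatter), was within the scatter. Compound 4 `Cn1c(-c2ccccc2)nc2c(NC3CCCC3)ncnc21` differs from compound 3 by cyclopentyl in place of cyclohexyl on a nitrogen on an aromatic ring. Within the data shown here, no measured pair isolates this change; the nearest comparison is compound 2, which carries cyclopentyl and gives a number within the scatter of compound 3 while also differing in the group on the aromatic ring. The two values of compound 2 and compound 3 thus give no sign that the ring size moves the number. Compound 4 is therefore expected to show a 1.2-fold higher number from compound 3 to compound 4 (0.09 log units; within the scatter), a step within the scatter. Compound 4 is estimated at 7 nM, with a range from 3 nM to 16 nM.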

Compound 4, inhibition constant: 2.8 nM
Estimate against measurement, compound 4: 2.5-fold (0.40 log units) above; the measured number lies below the stated range.
By their numbers in this assay, from the lowest: compound 4; then compounds 3, 2 and 1 (each within the scatter of the next).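

In this assay the ring on the amino nitrogen now has a step of its own, and a 2.0-fold lower number from compound 3 to compound 4 (0.31 log units; beyond the scatter) shows that cyclopentyl in place of cyclohexyl does move the number on this core, if only modestly. With the cyclopentylamino group held fixed, the aromatic ring also proves to matter: hydrogen in place of chloro on an aromatic carbon gives a 2.3-fold lower number from compound 2 to compound 4 (0.37 log units; beyond the scatter) as a second modest step. Nothing available explains why either change moves the number.

As far as these compounds go, whether a cyclobutyl ring or an open isopropyl chain on the amino nitrogen would carry the trend further remains open. So does whether the chloro step would hold with cyclohexylamino in place, and how a methoxy group on the aromatic ring would compare.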